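A few compounds are considered here, and "the series" means these few. Any claim that something is new, unique, unknown or untested is made for them only; others in the source may bear on it.

Compound 3 `Nc1ncnc2c1c(Oc1cc(C(F)(F)F)ccn1)nn2[C@@H]1CCCC[C@H]1O` was tested in an ADME assay on microsomes from liver (Homo sapiens) for metabolic stability, read by LC-MS, using NADPH, with a stated time of 10 min, tested at 10 uM; on this read-out lower numbers stand for a shorter-lived compound and higher numbers for a longer-lived compound. In this assay compound 3 gives > 2.41 h, which is a limit of the assay rather than a number. Compound 1 `Nc1ncnc2c1c(Oc1cc(C(F)(F)F)ccn1)nn2[C@H]1CC[C@@H](N)CC1` gives > 2.41 h, also a limit. Compound 2 `Nc1ncnc2c1c(Oc1cc(C(F)(F)F)ccn1)nn2[C@@H]1CC[C@H](N)C1` gives > 2.41 h, again a limit. Because all three values sit at the limit of > 2.41 h in this assay, at which 3 of the 3 values shown sit, the steps a step that the two limits leave unreadable from compound 1 to compound 3, a step that the two limits leave unreadable from compound 2 to compound 3 and a step that the two limits leave unreadable from compound 1 to compound 2 cannot be given a size. Compound 4 `Nc1ncnc2c1c(Oc1cc(C(F)(F)F)ccn1)nn2CC1CC1` differs from compound 3 by cyclopropylmethyl in place of 2-hydroxycyclohexyl on an aromatic nitrogen. Within the data shown here, none of the measured steps involves a group without donor or acceptor, so the size and direction of this change in this assay cannot be read from the three limits. Compound 4 is therefore expected to give about 2 h, between 0.8 h and 4 h, an estimated step of an at least 1.2-fold lower number from compound 3 to compound 4 (0.08 log units; that floor lies within the scatter).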

Compound 4, half-life: 1.87 h
Estimate against measurement, compound 4: 1.1-fold (0.03 log units) above; the range from low to high includes it.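

Among these compounds, compound 4 is the first compound here to give a number rather than a limit in this assay, so changes at this aromatic nitrogen now have a floor: an at least 1.2-fold lower number from compound 3 to compound 4 (0.11 log units; that floor lies within the scatter), an at least 1.2-fold lower number from compound 2 to compound 4 (0.11 log units; that floor lies within the scatter) and an at least 1.2-fold lower number from compound 1 to compound 4 (0.11 log units; that floor lies within the scatter). All three floors lie within the scatter, so cyclopropylmethyl is not shown to shorten the half-life, though the true gaps could be larger. The steps among compound 1, compound 2 and compound 3 still cannot be read: the limit of > 2.41 h in this assay, at which 3 of the 4 values shown sit.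

Still open, going by these compounds, is how an unsubstituted cyclohexyl or a longer chain such as butyl would read on this nitrogen. Also open, on these data alone, is whether a hydroxyl or an amine added to cyclopropylmethyl would change the half-life.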